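The source may hold more compounds than are shown below. What is called first, only, known or untested is meant among the compounds shown, and "the series" means these compounds.

Compound 1 `COc1cccc2cc(C(=O)NC3CCCCC3)c(=N)oc12`: > 70%
Compound 2 `COC(=O)/C(C#N)=C/c1cccc(OC)c1O`: > 70%
Compound 3 `COc1cccc2c1OC(C)(O)C(C(C)=O)=C2`: 24%

All three measured compounds were tested in an assay on HEK293 cells for displacement of a labelled ligand from adenosine receptor A2b (Homo sapiens), read by scintillation counting, with a stated time of 30 min, tested at 10 uM; a higher number here means more inhibition at the concentration tested (going by the name of the read-out), a lower number less inhibition. Compound 1 gives only a limit, > 70%, not a number. Compound 2 likewise gives a limit, > 70%. Compound 3 gives a number, 24%. Two of the three values thus sit at the limit of > 70% in this assay, at which 2 of the 3 values shown sit, and compound 1 is one of them; on these numbers compound 1 cannot be told apart from compound 2, while compound 3 stands well lower in this assay.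

Compound 4 `CCC(CO)NC(=O)c1cc2cccc(OC)c2oc1=N` has not yet been measured. It differs from compound 1 in one place: 1-(hydroxymethyl)propyl in place of cyclohexyl on an amide-type nitrogen. For the measured compounds named here, no pair of measured compounds that differ in a single place is available, so the size of this step has to be judged without a measured example. The step from compound 1 to compound 4 is expected to be a number at least 10 percentage points lower from compound 1 to compound 4 (that floor lies within the scatter), a change that may stay within the usual scatter. Compound 4 is expected to give 60% in this assay, with a likely range from 25% to 80%.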

Compound 4, a percentage reported as inhibition, at one concentration (the size of the read-out at that concentration, not a potency): 39%
Compound 4: the middle estimate sits 21 percentage points above what was measured; measured number inside the range.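

On the amide-type nitrogen, putting 1-(hydroxymethyl)propyl in place of cyclohexyl gives the only single-place comparison among these compounds, and in this assay it reads as a number at least 31 percentage points lower from compound 1 to compound 4 (beyond the scatter). This position is therefore not indifferent to what sits on it: the shared core alone does not keep the read-out high. The true step may be larger still, because compound 1 gives only a limit of the assay and not a number: the limit of > 70% in this assay, at which 2 of the 4 values shown sit.

This one step removes the cyclohexyl ring and brings in the hydroxymethyl-bearing chain at once, and the compounds shown do not separate those two parts. A plain butyl chain without oxygen, or a cyclohexyl ring carrying a hydroxyl group, on the same nitrogen could tell them apart.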